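A side-chain swap on the amine nitrogen of compound 3

The compounds below may be only part of what the source reports. "The series", "measured", "known", "first", "only" and "open" are said of these compounds alone.

Compound 3 `CC1=CCC[C@](C)(CC/C(C)=C/CC2=C(O)C(=O)C=C(N[C@H](CO)C(=O)O)C2=O)[C@@H]1C` was tested in an ADME assay on L1210 cells (Mus musculus) for cytotoxicity, with a stated time of 48 h; a higher number here means a weaker inhibitor, a lower number a stronger inhibitor. Compound 3 gives > 10 ug/mL, which is a limit and not a number, so it sits at the limit of > 10 ug/mL in this assay, at which 2 of the 3 values shown sit. Compound 1 `CC1=CCC[C@](C)(CC/C(C)=C/CC2=C(O)C(=O)C=C(N[C@@H](C(=O)O)[C@@H](C)O)C2=O)[C@@H]1C` gives > 10 ug/mL, also a limit. Compound 2 `C=C1[C@H](C)CCC[C@]1(C)CC/C(C)=C/CC1=C(O)C(=O)C=C(N[C@H](CO)C(=O)O)C1=O` gives a true number, 2.6 ug/mL.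

Compound 4 `CC1=CCC[C@](C)(CC/C(C)=C/CC2=C(O)C(=O)C=C(N[C@H](C(=O)O)C(C)C)C2=O)[C@@H]1C` keeps the rest of compound 3 and changes one group: 1-carboxy-2-methylpropyl in place of 1-carboxy-2-hydroxyethyl on an amine nitrogen. In words, this puts 1-carboxy-2-methylpropyl in place of 1-carboxy-2-hydroxyethyl on an amine nitrogen.

Going by the values given here, two measured steps bear on this only indirectly. The closer one is a step that the two limits leave unreadable from compound 1 to compound 3, which alters the same group on the amine nitrogen but cannot be sized. The other is an at least 3.8-fold higher number from compound 2 to compound 3 (0.58 log units; beyond the scatter), which swaps the group containing the carbon-only ring and leaves the amine nitrogen group untouched. Neither step therefore gives a size for this change, and no shift beyond the scatter is expected in this assay.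

The estimated step is a step that the limit leaves unreadable from compound 3 to compound 4. The reading may well turn out to be only a limit again. Compound 4 is expected at 12 ug/mL, with an estimated range from 4 ug/mL to 30 ug/mL.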

Compound 4, half-maximal inhibitory concentration: 3.4 ug/mL
For compound 4 the middle estimate is 3.5-fold (0.55 log units) above the measured one, and the stated range ends above it.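

In this assay, the group on the amine nitrogen now gives a readable change: 1-carboxy-2-methylpropyl in place of 1-carboxy-2-hydroxyethyl gives an at least 2.9-fold lower number from compound 3 to compound 4 (0.46 log units; beyond the scatter), and the same group in place of 1-carboxy-2-hydroxypropyl gives an at least 2.9-fold lower number from compound 1 to compound 4 (0.46 log units; beyond the scatter). Both steps lie beyond the usual scatter, so this position can shift the read-out while the group containing the carbon-only ring stays the same; before, only a change in that ring-containing group had given a step beyond the scatter. The step between compound 1 and compound 3 cannot be read, and both of those compounds remain at a limit: the limit of > 10 ug/mL in this assay, at which 2 of the 4 values shown sit.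

The new group differs from the old ones in both its hydroxyl and its carbon count, and these compounds do not separate the two changes; 1-carboxyethyl, or a longer chain ending in a carboxylic acid, would be a further test at this position. Also open, on these data alone, is whether 1-carboxy-2-methylpropyl would give a similar step when paired with the ring-containing group of compound 2.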